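Bromine on the fused ring in a second core

The source may hold more compounds than are shown below. What is called first, only, known or untested is meant among the compounds shown, and "the series" means these compounds.

Measured so far:
Compound 1, `COc1ccc(C2CC(c3ccc4ccccc4c3)=NN2C2=NC(=O)/C(=C3\C(=O)Nc4ccccc43)S2)cc1`: 12600 nM
Compound 2, `COc1ccc(C2CC(c3ccc4ccccc4c3)=NN2C2=NC(=O)/C(=C3\C(=O)Nc4ccc(Br)cc43)S2)cc1`: 210 nM
Compound 3, `COc1ccc(C2=NN(C3=NC(=O)/C(=C4\C(=O)Nc5ccccc54)S3)C(c3ccc(Cl)cc3)C2)cc1`: 100000 nM

The three measured compounds were tested in a functional assay on cells (Cancer cell lines, Homo sapiens) for cytotoxicity, read by sulforhodamine B assay, with a stated time of 48 h; a higher number here means a weaker inhibitor of growth, a lower number a stronger inhibitor of growth. Compound 1 `COc1ccc(C2CC(c3ccc4ccccc4c3)=NN2C2=NC(=O)/C(=C3\C(=O)Nc4ccccc43)S2)cc1` gives 12600 nM in this assay, while compound 2 `COc1ccc(C2CC(c3ccc4ccccc4c3)=NN2C2=NC(=O)/C(=C3\C(=O)Nc4ccc(Br)cc43)S2)cc1` gives 210 nM. The two differ by bromo in place of hydrogen on an aromatic carbon, and that change made a step of a 60-fold lower number from compound 1 to compound 2 (1.78 log units; beyond the scatter).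

Compound 3 `COc1ccc(C2=NN(C3=NC(=O)/C(=C4\C(=O)Nc5ccccc54)S3)C(c3ccc(Cl)cc3)C2)cc1` stands apart from compound 1 on a different core; the difference between the two cores is not broken down here. In this assay compound 3 gives 100000 nM, the highest of the three numbers, beyond the scatter from both compound 1 and compound 2.

Compound 4 `COc1ccc(C2=NN(C3=NC(=O)/C(=C4\C(=O)Nc5ccc(Br)cc54)S3)C(c3ccc(Cl)cc3)C2)cc1` has not yet been measured. For the measured compounds named here, it is built from compound 3 by bromo in place of hydrogen on an aromatic carbon, which is the same change as the one that took compound 1 to compound 2. Going by the values given here, since compound 3 starts from a much higher number than compound 1, the step in this assay is expected to lean the same way but is estimated as a 17-fold lower number from compound 3 to compound 4 (1.22 log units; beyond the scatter), resting on the single earlier step of a 60-fold lower number from compound 1 to compound 2 (1.78 log units; beyond the scatter). For compound 4 the expected value is 6000 nM, with an estimated range from 1000 nM to 40000 nM.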

Compound 4, concentration for total growth inhibition: 1480 nM
Estimate against measurement, compound 4: 4.1-fold (0.61 log units) above; the range from low to high includes it.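

In this assay, bromo in place of hydrogen on an aromatic carbon gave a 68-fold lower number from compound 3 to compound 4 (1.83 log units; beyond the scatter), a large step on the core of compound 3. Set beside the earlier step on the core of compound 1, the change carried over from one core to the other with its size preserved within the scatter: the same change on two cores in this assay, a 60-fold lower number (1.78 log units; beyond the scatter) from compound 1 to compound 2 and a 68-fold lower number (1.83 log units; beyond the scatter) from compound 3 to compound 4, 1.1-fold (0.05 log units) apart, within the scatter of two such steps. This holds for one group at one place, on two cores and in one assay; it does not show that the step would keep its size on any further core, it gives no explanation of why bromo has this effect, and it does not separate the contributions of the two cores, which differ from each other in more than one place.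

The compounds shown leave open whether fluoro, a methoxy group, an amine or a carboxylic acid in place of that hydrogen would give a step of similar size, or whether the effect belongs to bromo alone. They also leave open whether bromo on another carbon of the same aromatic ring would give a comparable step on either core.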